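Methyl on the anilide ring of compound 1

The compounds below may be only part of what the source reports. "The series", "measured", "known", "first", "only" and "open" are said of these compounds alone.

Compound 1 `CCCCCCCc1nc(N)n(CC(=O)Nc2ccccc2)c1-c1ccccc1Br` gives 7900 nM in a functional assay on MIA PaCa-2 cells (Homo sapiens) for antiproliferative activity, read by MTT assay, with a stated time of 48 h (on this read-out higher numbers stand for weaker inhibition and lower numbers for stronger inhibition), the highest of the three numbers measured. Compound 2 `Nc1nc(CC2CC2)c(-c2ccccc2Br)n1CC(=O)Nc1ccccc1` gives 6900 nM, and compound 3 `COc1ccc(Cc2nc(N)n(CC(=O)Nc3ccccc3)c2-c2ccccc2Br)cc1` gives 3200 nM. The two steps away from compound 1 are a 1.1-fold lower number from compound 1 to compound 2 (0.06 log units; within the scatter) and a 2.5-fold lower number from compound 1 to compound 3 (0.39 log units; beyond the scatter); both alter the group on the saturated chain carbon bound to an aromatic carbon, leaving the rest of the shared core untouched. Compound 4 `CCCCCCCc1nc(N)n(CC(=O)Nc2ccc(C)cc2)c1-c1ccccc1Br` changes a different part: methyl in place of hydrogen on an aromatic carbon. Among the compounds with values here, no measured step touches that ring, so the known steps give no direction for this change. For compound 4 the expected step is no change at the digits printed from compound 1 to compound 4 (within the scatter), not beyond the scatter. Compound 4 is therefore estimated at 7900 nM, with a range from 3500 nM to 18000 nM.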

Compound 4, half-maximal inhibitory concentration: 7000 nM
The estimate for compound 4 lay 1.1-fold (0.05 log units) above the measured number; low and high end bracket the measured number.
By their numbers in this assay, from the lowest: compound 3; then compounds 2, 4 and 1 (each within the scatter of the next).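

Changing phenyl to 4-methylphenyl gives a 1.1-fold lower number from compound 1 to compound 4 (0.05 log units; within the scatter) in this assay. This is the first step shown on this ring, and it shows that a single methyl can sit on this aromatic carbon, para to a large group, without moving the number beyond the scatter. No measurement at hand offers a reason for this result.

From the compounds shown here alone, whether an amine or a carboxylic acid at the same place would shift the number remains open. So does whether the methyl would have the same effect alongside the 4-methoxyphenyl group of compound 3.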